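Ortho Methyl for Bromo on Two Aryl Rings

The compounds below may be only part of what the source reports. "The series", "measured", "known", "first", "only" and "open" are said of these compounds alone.

Three compounds sharing a core were measured in a functional assay on MKN-74 cells (Homo sapiens) for antiproliferative activity, with a stated time of 24 h; on this read-out lower numbers stand for stronger inhibition and higher numbers for weaker inhibition:

Compound 1, `NC(=O)c1c(NC(=O)c2ccccc2Br)sc2c1CCN(C(=S)Nc1ccccc1Cl)C2`: 12900 nM
Compound 2, `Cc1ccccc1C(=O)Nc1sc2c(c1C(N)=O)CCN(C(=S)Nc1ccccc1Cl)C2`: 11000 nM
Compound 3, `NC(=O)c1c(NC(=O)c2ccccc2C(F)(F)F)sc2c1CCN(C(=S)Nc1ccccc1Br)C2`: 23900 nM

Compound 1 and compound 2 differ in one place, (methyl in place of bromo on an aromatic carbon). The step in this assay is a 1.2-fold lower number from compound 1 to compound 2 (0.07 log units; within the scatter), so the two values are not separated by this read-out. Compound 3 has the highest number of the three in this assay; it lies within the scatter of compound 1 and beyond the scatter of compound 2. How the core of compound 3 differs from the core of compound 1 is not broken down here.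

Compound 4, `Cc1ccccc1NC(=S)N1CCc2c(sc(NC(=O)c3ccccc3C(F)(F)F)c2C(N)=O)C1`, has not yet been measured. It differs from compound 3 by methyl in place of bromo on an aromatic carbon. The place description is the same as for the change from compound 1 to compound 2, though cut one bond further out it reads (2-bromophenyl)amino to (2-methylphenyl)amino rather than (2-bromophenyl)carbonyl to (2-methylphenyl)carbonyl. Among the compounds with values here, the only precedent is the step between compound 1 and compound 2, which stayed within the scatter. On that basis compound 4 is expected to sit close to compound 3 in this assay, with an estimated step of a 1.2-fold lower number from compound 3 to compound 4 (0.08 log units; within the scatter). The estimate for compound 4 in this assay is 20000 nM, with a range from 8000 nM to 50000 nM, the width reflecting that the precedent comes from a different aryl ring and a single pair.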

Compound 4, half-maximal inhibitory concentration: 47400 nM
Estimate against measurement, compound 4: 2.4-fold (0.37 log units) below, within the range that was stated.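

In this assay, the second case of methyl in place of bromo gives a 2.0-fold higher number from compound 3 to compound 4 (0.30 log units; within the scatter), so this read-out does not separate the two values. Set beside the first case, the step shows no difference between the two cores that can be told from the scatter: the same change on two cores in this assay, a 1.2-fold lower number (0.07 log units; within the scatter) from compound 1 to compound 2 and a 2.0-fold higher number (0.30 log units; within the scatter) from compound 3 to compound 4, 2.3-fold (0.37 log units) apart, within the scatter of two such steps. Within the data shown here, this shows only that the change stayed within the scatter in both pairs and that the two steps agree within their combined scatter; it does not show that the change is without effect in general, since there are just two pairs, and the bromo sits on the (2-bromophenyl)carbonyl part in the first pair and on the (2-bromophenyl)amino part in the second, so a difference of core cannot be parted from a difference of ring.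

The compounds shown leave open whether other groups in the same place on the ring, such as a methoxy, an amine or a carboxylic acid, would also stay within the scatter of the bromo compounds. They also leave open whether the two aryl rings would respond alike to such groups on a single core, which would need pairs that differ at each ring with the other held fixed.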